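Swapping a ring amine for an open chain amine

The source may report more compounds than this note shows. Statements on the series, on what has been measured and on what is new or still open speak of the compounds shown alone.

Three compounds share one core. Compound 1 `CCN(CC)c1ccc(C(F)(F)F)cc1NC(=O)c1cccnc1` gives 63200 nM in a functional assay on NALM-6 cells (Homo sapiens) for cytotoxicity, read by MTT assay, with a stated time of 48 h; a higher number here means a weaker inhibitor, a lower number a stronger inhibitor. Compound 2 `O=C(Nc1cc(C(F)(F)F)ccc1NC1CCCCC1)c1ccncc1` gives 59000 nM in this assay. Compound 3 `O=C(Nc1cc(C(F)(F)F)ccc1N1CCCC1)c1ccncc1` was reported as "not active" (no number reported) in this assay, so no number stands for it, and it cannot be placed against compound 1 or compound 2 on a scale. Compound 4 `CCN(CC)c1ccc(C(F)(F)F)cc1NC(=O)c1ccncc1` has not yet been measured. The change from compound 3 to compound 4 is diethylamino in place of pyrrolidin-1-yl on an aromatic carbon. Within the data shown here, no measured pair shows this exact step, so its size is unknown; the values of compound 1 and compound 2 show that amines of this kind on the core sit in the weak range. Compound 4 is expected to be a weak inhibitor, with an estimated value of 65000 nM (range 25000 nM to 200000 nM).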

Compound 4, half-maximal inhibitory concentration: 63600 nM
The estimate for compound 4 lay 1.0-fold (0.01 log units) above the measured number; the measured number falls inside the stated range.
By their numbers in this assay, from the lowest: compounds 2, 1 and 4 (each within the scatter of the next).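

In this assay diethylamino in place of cyclohexylamino on the aromatic carbon leaves the two compounds level (a 1.1-fold higher number from compound 2 to compound 4 (0.03 log units; within the scatter)), and so does pyridin-4-yl in place of pyridin-3-yl on the carbonyl carbon (a 1.0-fold higher number from compound 1 to compound 4 (0.00 log units; within the scatter)). Compound 4 thus has a measurable value with the open chain amine, whereas compound 3, with pyrrolidin-1-yl, has no number, so the step between them cannot be read. No measurement shown here explains these results.

As far as these compounds go, whether a piperidine ring or a primary amine on this aromatic carbon would shift the value remains open.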